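Halo swap on the pendant aryl ring: fluoro to chloro

The source may hold more compounds than are shown below. What is called first, only, known or untested is meant among the compounds shown, and "the series" means these compounds.

Measured so far:
compound 1, `O=C(Nc1ccccc1)c1c(NO)cc(-c2ccccc2)oc1=O`: 11600 nM
compound 2, `O=C(Nc1ccccc1)c1c(NO)cc(-c2ccc(F)cc2)oc1=O`: 10300 nM

Both numbers come from an ADME assay on Huh-7 cells (Homo sapiens) for cytotoxicity, read by a luciferase reporter and WST assay, with a stated time of 3 days; on this read-out higher numbers stand for lower toxicity in this test and lower numbers for higher toxicity in this test. Among the measured compounds shown here, compound 2 holds the lowest of the two numbers, with compound 1 as its nearest neighbour; the gap between them is the one measured step, a 1.1-fold lower number from compound 1 to compound 2 (0.05 log units; within the scatter), a fluoro in place of hydrogen on an aromatic carbon, and it stays within the scatter.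

Compound 3, `O=C(Nc1ccccc1)c1c(NO)cc(-c2ccc(Cl)cc2)oc1=O`, is not yet measured in this assay. It differs from compound 2 by chloro in place of fluoro on an aromatic carbon, that is 4-fluorophenyl to 4-chlorophenyl. For the measured compounds named here, the only measured step that bears on this position is the one from hydrogen to fluoro, and it moved nothing beyond the scatter. Going by the values given here, no measured step covers a fluoro-to-chloro exchange here, so nothing in the two values argues for a change larger than the scatter in either direction.

Compound 3 is therefore expected to sit near compound 2, with an estimated step of a 1.1-fold lower number from compound 2 to compound 3 (0.06 log units; within the scatter). The estimate for compound 3 in this assay is 9000 nM, in the range 4000 nM to 20000 nM.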

Compound 3, half-maximal cytotoxic concentration: 11000 nM
Estimate against measurement, compound 3: 1.2-fold (0.09 log units) below, within the range that was stated.
By their numbers in this assay, from the lowest: compounds 2, 3 and 1 (each within the scatter of the next).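

With chloro in place, the halogen exchange on the pendant ring can be read directly in this assay: the step is a 1.1-fold higher number from compound 2 to compound 3 (0.03 log units; within the scatter) and so 4-fluorophenyl and 4-chlorophenyl cannot be told apart on this read-out. Against the unsubstituted phenyl, the step is a 1.1-fold lower number from compound 1 to compound 3 (0.02 log units; within the scatter) and so a second halogen at this place, on an aromatic carbon para to a large group, also leaves the number within the scatter, and compound 1, compound 2 and compound 3 form a flat set with no order among them. No measurement shown gives a reason for this flat set.

On these data alone, these compounds carry only hydrogen, fluoro or chloro at this place, so it stays open whether an amine, a carboxylic acid or a longer chain such as butoxy on the same ring would move the number beyond the scatter. As far as these compounds go, how the read-out responds to changes elsewhere on the shared core also stays open, as the three compounds are identical there.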